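Swapping Methyl for Hydroxy on Compound 2

The source may report more compounds than this note shows. Statements on the series, on what has been measured and on what is new or still open speak of the compounds shown alone.

Three compounds with a shared core have numbers in a functional assay on the whole organism (arterial blood) with Rattus norvegicus as the target; on this read-out lower numbers stand for an effect already at smaller amounts and higher numbers for an effect only at larger amounts of compound. Compound 1 `Cc1nc2cnccc2n1CC1CCN(C(=O)CNC(c2ccccc2)c2ccccc2)CC1` gives 0.067 mg/kg, compound 2 `Cc1nc2cnccc2n1CC1CCN(C(=O)CC(C)(C)c2ccccc2)CC1` gives 0.012 mg/kg, and compound 3 `COC/C(=C\C(=O)N1CCC(Cn2c(C)nc3cnccc32)CC1)c1ccccc1` gives 0.022 mg/kg. Compound 2 and compound 3 lie within the usual scatter of each other, while compound 1 needs a clearly larger dose than compound 2. Compound 4 `Cc1nc2cnccc2n1CC1CCN(C(=O)CC(C)(O)c2ccccc2)CC1` is compound 2 with hydroxy in place of methyl on a saturated chain carbon bound to an aromatic carbon and two saturated chain carbons. For the measured compounds named here, no measured pair tests this swap, so the expectation is tentative. A modest rise is expected, the estimated step being a 2.5-fold higher number from compound 2 to compound 4 (0.40 log units; beyond the scatter). The estimate for compound 4 is 0.03 mg/kg, with an expected range of 0.008 mg/kg to 0.12 mg/kg.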

Compound 4, dose for 50% inhibition: 0.043 mg/kg
Estimate against measurement, compound 4: 1.4-fold (0.16 log units) below; low and high end bracket the measured number.
By their numbers in this assay, from the lowest: compounds 2, 3, 4 and 1 (each within the scatter of the next, the first and the last beyond it).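

For the compounds shown here, this pair gives the first direct reading at this position: hydroxy in place of methyl on a saturated chain carbon bound to an aromatic carbon and two saturated chain carbons gives a 3.6-fold higher number from compound 2 to compound 4 (0.55 log units; beyond the scatter) in this assay. The swap adds a hydrogen-bond donor and acceptor and carries a modest cost, with compound 4 at 0.043 mg/kg on this read-out. Nothing at hand explains the step.

From the compounds shown here alone, whether any replacement for methyl here would cost as much remains open. An amine or a fluorine on the same carbon would help to settle this.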